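Alanine to glycine on a melanocortin 4 agonist

The compounds below may be only part of what the source reports. "The series", "measured", "known", "first", "only" and "open" are said of these compounds alone.

Measured compounds:
compound 1, `CC(C)[C@H](NC(=O)CCN(C)C)c1cccc(F)c1N1CCN(C(=O)[C@@H]2CN(C(C)C)C[C@H]2c2ccc(C(F)(F)F)c(F)c2)CC1`: 47%
compound 2, `Cc1ccc(N2CCN(C(=O)[C@@H]3CN(C4CCOCC4)C[C@H]3c3ccc(Cl)cc3)CC2)c([C@@H](NC(=O)[C@@H](C)N)C(C)C)c1`: 56%
compound 3, `Cc1ccc(N2CCN(C(=O)[C@@H]3CNC[C@H]3c3ccc(Cl)cc3)CC2)c([C@@H](NC(=O)CCN(C)C)C(C)C)c1`: 72%

In a functional assay on CHO cells with Melanocortin receptor 4 (Homo sapiens) as the target, read by cAMP accumulation (a lower number here means a smaller maximal response, a higher number a larger maximal response), compound 2 gives 56%, the second highest of three numbers. Its nearest neighbour is compound 1 with 47%, a gap within the scatter, while compound 3 with 72% stands beyond the scatter above it. Compound 4, `Cc1ccc(N2CCN(C(=O)[C@@H]3CN(C4CCOCC4)C[C@H]3c3ccc(Cl)cc3)CC2)c([C@@H](NC(=O)CN)C(C)C)c1`, is not yet measured; it differs from compound 2 by hydrogen in place of methyl on a saturated chain carbon bound to an amine nitrogen and a carbonyl carbon. Within the data shown here, no measured pair shows this change, so its effect on intrinsic activity is unknown. A small step is expected, a number 1 percentage points lower from compound 2 to compound 4 (within the scatter), not beyond the scatter in either direction. Compound 4 is estimated at 55%, between 40% and 70%.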

Compound 4, intrinsic activity: the largest response reached, in percent of the reference agonist's: 114%
Compound 4: middle estimate off by 59 percentage points, on the low side; measured number above the stated range.
By their numbers in this assay, from the lowest: compounds 1 and 2 (each within the scatter of the next); then compound 3; then compound 4.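

In this assay, the loss of one methyl from the saturated chain carbon bound to an amine nitrogen and a carbonyl carbon gives a large step, a number 58 percentage points higher from compound 2 to compound 4 (beyond the scatter). Among these compounds, this position therefore responds strongly to a change of a single carbon, which the earlier compounds could not show, as no two of them differed in one place. Nothing shown here accounts for the step.

Going by these compounds, it remains open how an ethyl group on this carbon, or the methyl in the opposite configuration, would compare. Also open, on these data alone, is whether hydrogen in place of methyl gives a similar step with other groups on the shared core.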